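Anilino-pyrimidinyl urea series: compound 1 to compound 4

A few compounds are considered here, and "the series" means these few. Any claim that something is new, unique, unknown or untested is made for them only; others in the source may bear on it.

Measured so far:
- compound 1 `CCc1cccc(Nc2cc(NC(=O)Nc3cc(OC)cc(OC)c3)ncn2)c1`: 27.7%
- compound 2 `COc1cc(Nc2cc(NC(=O)Nc3c(Cl)cccc3Cl)ncn2)cc(OC)c1`: 68%
- compound 3 `COc1ccc(Nc2cc(NC(=O)Nc3c(Cl)cccc3Cl)ncn2)cc1C`: 45.1%

In a functional assay on NCI-H1581 cells (Homo sapiens) for inhibition, read by MTT assay, with a stated time of 48 h, tested at 10 uM (on this read-out higher numbers stand for more inhibition at the one concentration tested (going by the name of the read-out) and lower numbers for less inhibition), compound 1 stands lowest of the three numbers; compound 3 lies above it beyond the scatter, and compound 2 further above, also beyond the scatter. No two of these compounds differ in one place only, so no single step is known.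

Compound 4 `COc1cc(NC(=O)Nc2cc(Nc3cc(F)ccc3OC)ncn2)cc(OC)c1` keeps the shared core of compound 1 and differs in one place: 5-fluoro-2-methoxyphenyl in place of 3-ethylphenyl on a nitrogen on an aromatic ring. Within the data shown here, no measured pair shows the effect of this change. Within this assay a modest rise from compound 1 is expected, the step from a number 8.3 percentage points higher from compound 1 to compound 4 (within the scatter) being estimated near the edge of the scatter rather than clearly beyond it. Compound 4 is therefore estimated at 36%, within 15% to 58%.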

Compound 4, a percentage reported as inhibition, at one concentration (the size of the read-out at that concentration, not a potency): 42.1%
Compound 4: the middle estimate sits 6.1 percentage points below what was measured; the measured number falls inside the stated range.
By their numbers in this assay, from the lowest: compound 1; then compounds 4 and 3 (each within the scatter of the next); then compound 2.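

In this assay, the series now has its first single-place step, a number 14.4 percentage points higher from compound 1 to compound 4 (beyond the scatter), with 5-fluoro-2-methoxyphenyl in place of 3-ethylphenyl on a nitrogen on an aromatic ring. The number therefore moves beyond the scatter with the aryl group at this position while the rest of compound 1 stays fixed, though the step is modest. Nothing available explains this step.

The fluorine and the methoxy group enter together, so the step cannot be divided between them. On these data alone, how an amine or a carboxylic acid on this aryl group would read remains open.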